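The compounds below may be only part of what the source reports. "The series", "measured", "known", "first", "only" and "open" are said of these compounds alone.

The series shares one core, seen in compound 1 `O=C1C=C(Nc2ccc(I)cc2)C(=O)c2c1nc1n2[C@H]2OC[C@@H](O)[C@H]2OC1`, which carries a (4-iodophenyl)amino group and in a functional assay on ECa-109 cells for inhibition, with ECa-109 cell line (Homo sapiens) as the target, read by sulforhodamine B assay (a lower number here means a stronger inhibitor, a higher number a weaker inhibitor), gives 2300 nM. Compound 2 `O=C1C=C(NC2CCCC2)C(=O)c2c1nc1n2[C@H]2OC[C@@H](O)[C@H]2OC1` replaces that group with a cyclopentylamino group. In this assay compound 2 gives only a limit, > 16000 nM. Compound 3 `CCCN(CCC)C1=CC(=O)c2nc3n(c2C1=O)[C@H]1OC[C@@H](O)[C@H]1OC3` carries a dipropylamino group instead. In this assay compound 3 also gives only a limit, > 16000 nM. Compound 3 thus stands at the limit of > 16000 nM in this assay, at which 2 of the 3 values shown sit, together with compound 2, and the step of an at least 6.9-fold higher number from compound 1 to compound 3 (0.84 log units; beyond the scatter) and the step of an at least 6.9-fold higher number from compound 1 to compound 2 (0.84 log units; beyond the scatter) both show that leaving the 4-iodophenyl group on the amine nitrogen weakens inhibition, while the step that the two limits leave unreadable from compound 2 to compound 3 cannot be sized from two limits. Compound 4 `O=C1C=C(Nc2ccccc2F)C(=O)c2c1nc1n2[C@H]2OC[C@@H](O)[C@H]2OC1` is reached from compound 3 by the change ((2-fluorophenyl)amino in place of dipropylamino on a double-bonded ring carbon). This restores an aryl amine of the kind seen in compound 1, which gives 2300 nM, so the step of an at least 6.9-fold higher number from compound 1 to compound 3 (0.84 log units; beyond the scatter) read in reverse is the guide, and a return toward that level is expected. Compound 4 is therefore expected to show the step of an at least 4.5-fold lower number from compound 3 to compound 4 (0.66 log units; beyond the scatter) in this assay, a fall in the number beyond the scatter. The value expected for compound 4 is 3500 nM, between 1200 nM and 12000 nM.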

Compound 4, half-maximal inhibitory concentration: 2760 nM
Compound 4: the middle estimate sits 1.3-fold (0.10 log units) above what was measured, within the range that was stated.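

With compound 4, the aryl amine on this double-bonded ring carbon no longer rests on compound 1 alone: in this assay, 2-fluorophenyl on the amine nitrogen cannot be told apart from 4-iodophenyl, as the result shows (a 1.2-fold higher number from compound 1 to compound 4 (0.08 log units; within the scatter)). Set against the two non-aromatic amines, the same aryl amine again lowers the number, as seen in an at least 5.7-fold lower number from compound 3 to compound 4 (0.76 log units; beyond the scatter) and in an at least 5.7-fold lower number from compound 2 to compound 4 (0.76 log units; beyond the scatter), so the earlier gap is not tied to the iodine of compound 1. Compound 2 keeps the amine hydrogen and compound 3 lacks it, yet each gives only a limit of the assay, so the amine hydrogen alone does not bring a measured number among these compounds: the limit of > 16000 nM in this assay, at which 2 of the 4 values shown sit.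

The aryl groups shown all carry a halogen, which leaves open whether an unsubstituted phenyl, a methoxyphenyl or a benzyl group on the amine nitrogen would stay at this level. From the compounds shown here alone, compound 1 and compound 4 differ in both the halogen and its place on the ring, so the effect of each taken alone remains open, and the true values of compound 2 and compound 3 remain unknown.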